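Benzylsulfanyl in place of amino on the core of compound 3

The compounds below may be only part of what the source reports. "The series", "measured", "known", "first", "only" and "open" are said of these compounds alone.

Three compounds have numbers. In a functional assay on EL4 cells (Mus musculus) for inhibition, tested at 100 uM (a lower number here means less inhibition, a higher number more inhibition at the concentration tested (going by the name of the read-out)), compound 1 `[O-][n+]1ccc2c(c1)ncn2[C@H]1C[C@H](O)[C@@H](CO)O1` gives only a limit of the assay, < 5%. Compound 2 `Sc1[nH]ccc2ncnc1-2` likewise reaches only a limit, < 5%. Going by the values given here, compound 3 `Nc1nccc2c1ncn2[C@H]1C[C@H](O)[C@@H](CO)O1` gives 89% and is the sole value that is a number; the two others sit at the limit of < 5% in this assay, at which 2 of the 3 values shown sit. Compound 4 `OC[C@H]1O[C@@H](n2cnc3c(SCc4ccccc4)nccc32)C[C@@H]1O` is not yet measured and differs from compound 3 by benzylsulfanyl in place of amino on an aromatic carbon. Among the compounds with values here, no step between measured compounds exists, so no size can be borrowed from another pair, and compounds 1 and 2 differ from compound 3 in more than one place. A loss of inhibition is expected for compound 4, roughly a number 49 percentage points lower from compound 3 to compound 4 (beyond the scatter), giving an estimated 40% within 5% to 80%.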

Compound 4, a percentage reported as inhibition, at one concentration (the size of the read-out at that concentration, not a potency): 11%
Compound 4: the middle estimate sits 29 percentage points above what was measured, within the range that was stated.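

Going by these compounds alone, this is the first comparison on the core that differs in one place: on an aromatic carbon next to the ring nitrogen, benzylsulfanyl in place of amino gives a number 78 percentage points lower from compound 3 to compound 4 (beyond the scatter) in this assay. Compound 4 gives 11%, a number and not a limit, so this step has a measured size. The other two compounds offer no such size: the limit of < 5% in this assay, at which 2 of the 4 values shown sit.

Going by these compounds, whether the loss goes with the sulfur or with the added aromatic ring stays open. A methylsulfanyl or a benzylamino group on the same carbon would separate the two.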